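A few compounds are considered here, and "the series" means these few. Any claim that something is new, unique, unknown or untested is made for them only; others in the source may bear on it.

Measured in a functional assay on Huh-7 cells (Homo sapiens) for inhibition, read by MTT assay, with a stated time of 72 h; a higher number here means a weaker inhibitor, a lower number a stronger inhibitor:
Compound 1 `Nc1ncnc2c1c(-c1cnc3[nH]ccc3c1)nn2CCCCCCCCC(=O)NO` gives 7380 nM
Compound 2 `Nc1ncnc2c1c(-c1cnc3[nH]ccc3c1)nn2CCCCCCC(=O)NO` gives 50900 nM

Compound 1 has the lower of the two numbers, so it is the stronger inhibitor of this pair. Compound 3 `Nc1nc2cc(-c3nn(CCCCCCCCC(=O)NO)c4ncnc(N)c34)ccc2o1` keeps the chain and core of compound 1 but exchanges one group on an aromatic carbon: a group of 10 heavy atoms (7 carbon, 2 nitrogen, 1 oxygen; one five-membered aromatic ring with 2 hetero atoms, one six-membered aromatic ring of carbon only) in place of a group of 9 heavy atoms (7 carbon, 2 nitrogen; one five-membered aromatic ring with 1 hetero atom, one six-membered aromatic ring with 1 hetero atom), on an aromatic carbon. Among the measured compounds shown here, no measured step covers this exchange. For the measured compounds named here, the only step, a 6.9-fold higher number from compound 1 to compound 2 (0.84 log units; beyond the scatter), changes the chain instead, so it shows only how far one change can move the number in this assay. A step of similar size is expected here, with a tentative lean towards a lower number. The estimate for compound 3 is 2000 nM, with an expected range of 300 nM to 9000 nM. This estimate means an expected 3.7-fold lower number from compound 1 to compound 3 (0.57 log units; beyond the scatter).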

Compound 3, half-maximal inhibitory concentration: 1470 nM
Estimate against measurement, compound 3: 1.4-fold (0.13 log units) above; low and high end bracket the measured number.
By their numbers in this assay, from the lowest: compound 3; then compound 1; then compound 2.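

The earlier compounds shown here changed only the chain, whereas this pair shows that the group on the aromatic carbon also moves the number in this assay: 2-amino-1,3-benzoxazol-5-yl gives a 5.0-fold lower number from compound 1 to compound 3 (0.70 log units; beyond the scatter), so compound 3 is the stronger inhibitor of this pair. Nothing available explains this gain. From the compounds shown here alone, it remains open whether the amine on this group matters, which a methyl group in its place could test, and whether the same exchange would help on the shorter chain of compound 2.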